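Adding a Phenyl to a Urea Series Stuck at the Limit

The compounds below may be only part of what the source reports. "The series", "measured", "known", "first", "only" and "open" are said of these compounds alone.

Compound 1, `Cc1cnn(C(=O)NCc2ccc(OCc3ccccc3)cc2)c1`, was tested in an assay on membranes from brain for binding affinity to neutral cholesterol ester hydrolase 1 (Mus musculus), read by fluorescence, with stated times of 1 h and 30 min; on this read-out higher numbers stand for weaker inhibition and lower numbers for stronger inhibition. In this assay compound 1 gives only a limit, > 100000 nM, so no true number is known for it. Compound 2, `O=C(NCc1ccc(OCc2ccccc2)cc1)n1cccn1`, differs from compound 1 by hydrogen in place of methyl on an aromatic carbon. In this assay compound 2 likewise gives only a limit, > 100000 nM. The step from one to the other, a step that the two limits leave unreadable from compound 1 to compound 2, therefore cannot be sized, because of the limit of > 100000 nM in this assay, at which 2 of the 2 values shown sit.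

Compound 3, `Cc1cnn(C(=O)NCc2ccc(OC(c3ccccc3)c3ccccc3)cc2)c1`, is the compound to be measured. It differs from compound 1 by phenyl in place of hydrogen on a saturated chain carbon bound to an aromatic carbon and an oxygen on an aromatic ring. Within the data shown here, no measured step touches this kind of change; the only step available, from compound 1 to compound 2, concerns a different position and is itself unreadable. On the numbers shown, both measured compounds sit at the limit, so the most that can be said is where compound 1 stands: at the limit.

Compound 3 is therefore expected to give about 100000 nM, in a range from 20000 nM to 300000 nM. The step this estimate implies, a number no higher from compound 1 to compound 3 (the limit leaves the size open), is expected to be none beyond the scatter, with a limit again the likeliest outcome.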

Compound 3, half-maximal inhibitory concentration: > 100000 nM
Compound 3: no number, only a limit; the forecaster's own chance of this, stated with the estimate: 70%; the middle value lies on the limit itself.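

Compound 3, like compounds 1 and 2, gives no number, so the step from compound 1 to compound 3 cannot be read, because each result is only a limit: the limit of > 100000 nM in this assay, at which 3 of the 3 values shown sit. The compounds shown leave open how strongly any of them inhibits the enzyme, and whether phenyl in place of hydrogen on that saturated chain carbon changes inhibition at all.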